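Adding a Trifluoromethoxy Group to the Pendant Phenyl

The source may hold more compounds than are shown below. What is called first, only, known or untested is meant among the compounds shown, and "the series" means these compounds.

Compound 3 `Cn1cncc1C(OCc1ccc(C#N)nc1-c1ccccc1)c1ccc(C#N)cc1` gives 19 nM in a functional assay on NIH3T3 cells (Mus musculus) (on this read-out lower numbers stand for an effect already at smaller amounts and higher numbers for an effect only at larger amounts of compound), the highest number among the three measured compounds. Compound 1 `Cn1cncc1C(OCc1ccc(C#N)nc1-c1cccc(Cl)c1)c1ccc(C#N)cc1` gives 1.8 nM, and compound 2 `CN1CCN(c2nc(COC(c3ccc(C#N)cc3)c3cncn3C)c(-c3cccc(Cl)c3)cc2C#N)CC1` gives 2 nM. Among the measured compounds shown here, only one measured step touches compound 3: an 11-fold higher number from compound 1 to compound 3 (1.02 log units; beyond the scatter), a large shift that came from removing a single substituent from this phenyl ring. Compound 4 `Cn1cncc1C(OCc1ccc(C#N)nc1-c1ccc(OC(F)(F)F)cc1)c1ccc(C#N)cc1` differs from compound 3 by trifluoromethoxy in place of hydrogen on an aromatic carbon. Because an 11-fold higher number from compound 1 to compound 3 (1.02 log units; beyond the scatter) shows the bare ring giving the weaker result, a lower number is expected for compound 4, though the new group is not the chloro of compound 1, so the size remains uncertain. Compound 4 is therefore estimated at 6 nM, with a range from 1.5 nM to 25 nM, an expected step of a 3.2-fold lower number from compound 3 to compound 4 (0.50 log units; beyond the scatter) in this assay.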

Compound 4, half-maximal effective concentration: 4 nM
Compound 4: middle estimate off by 1.5-fold (0.18 log units), on the high side, within the range that was stated.
By their numbers in this assay, from the lowest: compounds 1, 2 and 4 (each within the scatter of the next, the first and the last beyond it); then compound 3.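

In this assay, among the compounds shown here, the step of a 4.8-fold lower number from compound 3 to compound 4 (0.68 log units; beyond the scatter) shows that chloro is not the only group that can lift the bare phenyl ring: trifluoromethoxy, para to a large group, also lowers the number. The swap of 3-chlorophenyl for 4-(trifluoromethoxy)phenyl, a 2.2-fold higher number from compound 1 to compound 4 (0.35 log units; beyond the scatter), shows that this gain falls somewhat short of the one seen with chloro. No measurement here offers an explanation for either step. Going by these compounds, whether a smaller methoxy group or an amine at this same place would also lower the number remains open.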